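A few compounds are considered here, and "the series" means these few. Any claim that something is new, unique, unknown or untested is made for them only; others in the source may bear on it.

Compound 2 `O=C(O)c1ccc(COc2ccc(OCCOCCNC3CCCC3)cc2)cc1` is the weaker of the two measured compounds in a functional assay on SK-OV-3 cells (Homo sapiens) for inhibition, read by CCK-8 assay, with a stated time of 70 h; on this read-out lower numbers stand for stronger inhibition and higher numbers for weaker inhibition. In this assay compound 2 reaches only a limit of the assay, > 100000 nM, so no number is known for it. Compound 1 `COC(=O)c1cccc(COc2ccc(OCCOCCNC3CCCC3)cc2)c1` in this assay gives 45500 nM. Among the measured compounds shown here, the single measured step, an at least 2.1-fold higher number from compound 1 to compound 2 (0.34 log units; beyond the scatter), points toward weaker inhibition, and its size is set by the limit of > 100000 nM in this assay, at which 1 of the 2 values shown sits, so its true extent is uncertain. Compound 3 `O=[N+]([O-])c1ccccc1COc1ccc(OCCOCCNC2CCCC2)cc1` differs from compound 2 by 2-nitrophenyl in place of 4-carboxyphenyl on a saturated chain carbon bound to an oxygen on an aromatic ring. The group that leaves is the same 4-carboxyphenyl whose arrival weakened inhibition in the measured step, and the group that enters, like the 3-(methoxycarbonyl)phenyl of compound 1, carries no hydrogen-bond donor. The step toward compound 3 is therefore expected to move back toward stronger inhibition, at least modestly. Compound 3 is expected to give about 40000 nM, between 15000 nM and 120000 nM, which is a step of an at least 2.5-fold lower number from compound 2 to compound 3 (0.39 log units; beyond the scatter).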

Compound 3, half-maximal inhibitory concentration: 5370 nM
The estimate for compound 3 lay 7.4-fold (0.87 log units) above the measured number, outside the stated range (below it).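

Changing the group at this place, on a saturated chain carbon bound to an oxygen on an aromatic ring, can also strengthen inhibition: in this assay, 2-nitrophenyl in place of 3-(methoxycarbonyl)phenyl gives an 8.5-fold lower number from compound 1 to compound 3 (0.93 log units; beyond the scatter). Compound 2 has only a limit of the assay, > 100000 nM, and no number. The change from 4-carboxyphenyl to 2-nitrophenyl gives an at least 18-fold lower number from compound 2 to compound 3 (1.27 log units; beyond the scatter), and the true size of this step remains uncertain: the limit of > 100000 nM in this assay, at which 1 of the 3 values shown sits.

These three compounds differ both in the group carried on the phenyl ring and in where it sits, so they cannot separate the effect of the nitro group from that of its place on the ring. Going by these compounds, whether 4-nitrophenyl, 2-aminophenyl or unsubstituted phenyl would give similar inhibition remains open.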